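Pyridyl vinyl sulfones: cytotoxicity notes on BV-2 cells

The source may hold more compounds than are shown below. What is called first, only, known or untested is meant among the compounds shown, and "the series" means these compounds.

Measured so far:
- compound 1, `COc1ccccc1S(=O)(=O)/C=C/c1cccnc1`, gives 100% in an ADME assay on BV-2 cells (Mus musculus) for cytotoxicity, with a stated time of 24 h, tested at 10 uM; on this read-out higher numbers stand for a weaker effect at the one concentration tested and lower numbers for a stronger effect.
- compound 2, `COc1cccc(S(=O)(=O)/C=C/c2cccnc2)c1`, gives 100% in this assay.
- compound 3, `COc1ccccc1S(=O)(=O)/C=C/c1ccncc1`, gives 96.8% in this assay.

One step is counted. From compound 1 to compound 3 the change is pyridin-4-yl in place of pyridin-3-yl on a double-bonded chain carbon bound to a double-bonded chain carbon, and in this assay this gives a number 3.2 percentage points lower from compound 1 to compound 3 (within the scatter), so the two read-outs are not separated by the assay's scatter. Compound 2 and compound 1 are level at the digits given; the difference between the two cores is not broken down here, and their values show no separation.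

Compound 4, `COc1cccc(S(=O)(=O)/C=C/c2ccncc2)c1`, has not been measured. It stands to compound 2 as compound 3 stands to compound 1: the change is pyridin-4-yl in place of pyridin-3-yl on a double-bonded chain carbon bound to a double-bonded chain carbon, and the place lines match word for word, so this is the same change. Going by the values given here, the step expected from compound 2 to compound 4 in this assay is a number 2 percentage points lower from compound 2 to compound 4 (within the scatter), resting on the single earlier step of a number 3.2 percentage points lower from compound 1 to compound 3 (within the scatter), which was within scatter. Compound 4 is therefore estimated at 98%, with the likely span from 90% to 105%.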

Compound 4, a percentage reported as activity, at one concentration (the size of the read-out at that concentration, not a potency): 84.3%
Beside the measured number, compound 4's estimate is 13.7 percentage points above it; measured number below the stated range.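

In this assay, pyridin-4-yl in place of pyridin-3-yl on a double-bonded chain carbon gives a number 15.7 percentage points lower from compound 2 to compound 4 (beyond the scatter), and only on this core does the change clear the scatter. Set beside the same change on the core of compound 1, the two steps cannot be told apart: the same change on two cores in this assay, a number 3.2 percentage points lower (within the scatter) from compound 1 to compound 3 and a number 15.7 percentage points lower (beyond the scatter) from compound 2 to compound 4, 12.5 percentage points apart, within the scatter of two such steps. The two pairs are therefore compatible with one shared effect of this change, but they do not establish one, they do not show that the core alters its size, and they are too few to support a rule for the series.

The compounds shown leave open how the read-out responds when the methoxy group is exchanged for an amine or a carboxylic acid, and whether the same change keeps its direction on such cores. They also leave open whether the lower number for compound 4 holds at other concentrations or exposure times, since each compound is represented by a single read-out.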